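Working notes: 3-fluorophenyl in place of 4-methylphenyl

This account rests on a few compounds, and the source may have more. Where it says the series, first, only, none or still open, it means among the compounds named here.

Of the compounds shown here, two have been read so far: compound 1 (`O=C(CN1CCN(C(=O)c2cccc(F)c2)CC1)N1CCN(CCCc2c[nH]c3ccc(F)cc23)CC1`) and compound 2 (`COc1ccc2[nH]cc(CCCN3CCN(C(=O)CN4CCN(C(=O)c5ccc(C)cc5)CC4)CC3)c2c1`). In an ADME assay on SH-SY5Y cells (Homo sapiens) for cytotoxicity, read by MTT assay, with a stated time of 72 h (a higher number here means a weaker inhibitor, a lower number a stronger inhibitor), compound 1 gives 169000 nM as a plain number. Compound 2 gives > 200000 nM as its reading, which is a limit of the assay and not a number, so no exact figure exists for it.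

Compound 3 (`COc1ccc2[nH]cc(CCCN3CCN(C(=O)CN4CCN(C(=O)c5cccc(F)c5)CC4)CC3)c2c1`) has not been measured. It has 3-fluorophenyl in place of 4-methylphenyl on a carbonyl carbon. Going by the values given here, no measured pair yet shows what a change of this kind does in this assay and the expectation therefore stays modest. Among the compounds with values here, with compound 1 at 169000 nM as the only plain number, compound 3 is expected to remain in the same high range. The expected at least 1.1-fold lower number from compound 2 to compound 3 (0.04 log units; that floor lies within the scatter) is small, no larger than the usual scatter, and points, if anywhere, towards a lower number. For compound 3 the estimate is 180000 nM with an expected range from 110000 nM to 280000 nM if a number is reported at all.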

Compound 3, half-maximal inhibitory concentration: > 200000 nM
Compound 3: no number, only a limit (the forecaster's own chance of this, stated with the estimate: 45%); middle value at least 1.1-fold (0.04 log units) from the limit.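

Working notes: reading of compound 3

In this assay compound 3 gives > 200000 nM, which is a limit of the assay and not a number. Going by these compounds alone, with 3-fluorophenyl held on the carbonyl carbon, methoxy in place of fluoro on an aromatic carbon gives the first readable single-place step, an at least 1.1-fold higher number from compound 1 to compound 3 (0.07 log units; that floor lies within the scatter), and as a floor it does not settle whether the true step exceeds the scatter. The change of 4-methylphenyl to 3-fluorophenyl on a carbonyl carbon cannot be read because compound 2 and compound 3 both carry a limit and no number: the limit of > 200000 nM in this assay, at which 2 of the 3 values shown sit.

The compounds shown leave open whether any group on the carbonyl carbon moves the reading in this series, and how far past the limit compound 2 and compound 3 lie. From the compounds shown here alone, whether an amine or a carboxylic acid in place of 3-fluorophenyl on that carbonyl carbon would bring the methoxy compounds to a plain number also stays open.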